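Adding hydroxymethyl to compound 2: cytotoxicity outlook

The source may report more compounds than this note shows. Statements on the series, on what has been measured and on what is new or still open speak of the compounds shown alone.

Of the compounds shown here, two have been read in an ADME assay on HEp-2 cells (Homo sapiens) for cytotoxicity, read by CCK-8 assay, with a stated time of 6 days; a lower number here means that less compound is tolerated, a higher number that more compound is tolerated. Compound 1 `Cc1ccc2nc(Cn3c(=O)n(C4CC4)c4ccncc43)c(CCCCO)n2c1` returns only a limit and not a number in this assay, namely > 100000 nM. Among the measured compounds shown here, compound 2 `O=c1n(Cc2cn3ccc(Cl)cc3n2)c2cnccc2n1C1CC1` gives 22300 nM in this assay; this is the only numeric value shown, the other entry being (the limit of > 100000 nM in this assay, at which 1 of the 2 values shown sits). Compound 3 `O=c1n(Cc2nc3cc(Cl)ccn3c2CO)c2cnccc2n1C1CC1` is not yet measured. It differs from compound 2 in one place: hydroxymethyl in place of hydrogen on an aromatic carbon, the new group standing next to the ring nitrogen and next to the ring atom that bears a large group. For the measured compounds named here, no step between two measured compounds exists to set a scale for this change. For compound 3 a modest shift toward more compound tolerated is expected, the expected step being a 1.6-fold higher number from compound 2 to compound 3 (0.20 log units; within the scatter), possibly not beyond the scatter. Compound 3 is estimated at 35000 nM in this assay, within a range of 12000 nM to 100000 nM.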

Compound 3, half-maximal cytotoxic concentration: > 100000 nM
Compound 3: only a limit was reported; the forecaster's own chance of this, stated with the estimate: 30%; middle value at least 2.8-fold (0.45 log units) away from the limit.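

Hydroxymethyl in place of hydrogen on an aromatic carbon, next to the ring nitrogen and next to the ring atom that bears a large group, gives the first readable step of this series in this assay: an at least 4.4-fold higher number from compound 2 to compound 3 (0.65 log units; beyond the scatter). At this position, the change therefore moves the read-out beyond the scatter, toward more compound tolerated. In this assay compound 3 gives only a limit and not a number, so the full size of the step stays unknown, and compound 3 now shares that limit with compound 1: the limit of > 100000 nM in this assay, at which 2 of the 3 values shown sit.

The compounds shown leave open whether the step is particular to hydroxymethyl or also appears with an aminomethyl group or a carboxylic acid on the same carbon. They also leave open whether a longer chain bearing a terminal hydroxyl gives the same step on the core of compound 2.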